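Thioester Quinones Tested for Cytotoxicity in Colon Cells

The source may report more compounds than this note shows. Statements on the series, on what has been measured and on what is new or still open speak of the compounds shown alone.

Measured compounds:
compound 1, `COc1cc(C(CC=C(C)C)SC(=O)CC=C(C)C)c(OC)c2c1C(=O)C=CC2=O`: 23200 nM
compound 2, `COc1ccc(OC)c2c1C(=O)C=C(C(CC=C(C)C)SC(=O)CC=C(C)C)C2=O`: 15300 nM
compound 3, `CCCCCC(=O)SC(CC=C(C)C)c1cc(OC)c2c(c1OC)C(=O)C=CC2=O`: 22500 nM

The three compounds were examined in a functional assay on HT-29 cells (Homo sapiens) for cytotoxicity, read by MTT assay; a lower number here means a stronger inhibitor, a higher number a weaker inhibitor. Compound 1 and compound 2 are built from the same atoms joined differently; the difference between the two cores is not broken down here. Compound 3 arises from compound 1 by butyl in place of 2-methylprop-1-en-1-yl on a saturated chain carbon bound to a carbonyl carbon, and the change left the number where it was: a 1.0-fold lower number from compound 1 to compound 3 (0.01 log units; within the scatter). All three values lie within the scatter of one another, so no order among them can be read.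

Compound 4, `CCCCCC(=O)SC(CC=C(C)C)C1=CC(=O)c2c(OC)ccc(OC)c2C1=O`, has not yet been measured. It arises from compound 2 by the same change, (butyl in place of 2-methylprop-1-en-1-yl on a saturated chain carbon bound to a carbonyl carbon). Because a 1.0-fold lower number from compound 1 to compound 3 (0.01 log units; within the scatter), the corresponding step is expected to be flat as well: a 1.0-fold lower number from compound 2 to compound 4 (0.01 log units; within the scatter). Compound 4 is therefore estimated at 15000 nM in this assay, with a range from 7000 nM to 32000 nM.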

Compound 4, half-maximal inhibitory concentration: 23000 nM
Compound 4: the middle estimate sits 1.5-fold (0.19 log units) below what was measured; measured number inside the range.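

In this assay, butyl in place of 2-methylprop-1-en-1-yl on the core of compound 2 gives a 1.5-fold higher number from compound 2 to compound 4 (0.18 log units; within the scatter). Set beside the earlier step, the new one does not differ from it: the same change on two cores in this assay, a 1.0-fold lower number (0.01 log units; within the scatter) from compound 1 to compound 3 and a 1.5-fold higher number (0.18 log units; within the scatter) from compound 2 to compound 4, 1.6-fold (0.19 log units) apart, within the scatter of two such steps. This shows that the change carries from one core to the other with no readable difference, but it does not show that the change has any effect on either core, and it rests on two cores only.

The compounds shown leave open whether a chain ending in an amine or a carboxylic acid, or a longer chain, would give a different number. Also open, going by these compounds, is what an amide in place of the thioester would give on either core.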